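Trifluoromethyl in Place of Trifluoromethoxy on a Shared Core

A few compounds are considered here, and "the series" means these few. Any claim that something is new, unique, unknown or untested is made for them only; others in the source may bear on it.

Compound 1, `Cc1cccc(-c2c(N)n[nH]c2C)c1`, sits at a limit in an assay on Sf9 cells for inhibition of inhibitor of nuclear factor kappa-B kinase subunit epsilon (Homo sapiens), read by ADP-Glo, with a stated time of 60 min (a higher number here means a weaker inhibitor, a lower number a stronger inhibitor), giving > 100000 nM.
Compound 2, `Cc1[nH]nc(N)c1-c1cccc(Cl)c1`, gives 93400 nM in this assay.
Compound 3, `Cc1[nH]nc(N)c1-c1cccc(OC(F)(F)F)c1`, sits at a limit in this assay, giving > 100000 nM.

Compound 3 therefore stands at a limit, not at a number, and it shares that position with compound 1, as the limit of > 100000 nM in this assay, at which 2 of the 3 values shown sit, shows; compound 2 is the only one of the three with a measured number, and it lies close to that limit. The steps among them are small or unreadable: an at least 1.0-fold lower number from compound 1 to compound 2 (0.02 log units; that floor lies within the scatter), a step that the two limits leave unreadable from compound 1 to compound 3, an at least 1.0-fold higher number from compound 2 to compound 3 (0.02 log units; that floor lies within the scatter).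

Compound 4, `Cc1[nH]nc(N)c1-c1cccc(C(F)(F)F)c1`, has not yet been measured. It differs from compound 3 by trifluoromethyl in place of trifluoromethoxy on an aromatic carbon. Among the compounds with values here, the steps that bear on this change are those in which the same position carried methyl, chloro or trifluoromethoxy, and none of them moved the reading beyond the scatter or out of the region of the limit. The expectation for compound 4 in this assay is therefore no change beyond the scatter, with a fair chance of a reading again at the limit, so that the expected step is a number no higher from compound 3 to compound 4 (the limit leaves the size open). Compound 4 is estimated at 100000 nM, with an expected range from 40000 nM to 300000 nM.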

Compound 4, half-maximal inhibitory concentration: > 100000 nM
Compound 4 was reported as a limit; the forecaster's own chance of this, stated with the estimate: 65%; the middle value lies on the limit itself.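

The reading of compound 4 is a limit and not a number, as are those of compound 1 and compound 3, so the steps from those two compounds to compound 4 cannot be read, and nothing can be said about what removing the oxygen of trifluoromethoxy does to the size of the effect. In this assay, within the data shown here, the only step that can be read is an at least 1.0-fold higher number from compound 2 to compound 4 (0.02 log units; that floor lies within the scatter), so trifluoromethyl cannot be told apart from chloro at this aromatic carbon. Trifluoromethyl, which has no hydrogen-bond acceptor where trifluoromethoxy has one, now joins methyl and trifluoromethoxy, leaving chloro as the only one of these four groups with a measured number, and that number lies close to the ceiling: the limit of > 100000 nM in this assay, at which 3 of the 4 values shown sit.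

The compounds shown leave open whether any group on this aromatic carbon can bring the reading well clear of that limit, since an amine, a carboxylic acid or a longer chain such as butyl does not appear among them. They also leave open whether a change elsewhere on the shared core would make differences between these four groups readable.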